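Swapping the Amide Nitrogen Group in a Paw Edema Inhibition Series

The compounds below may be only part of what the source reports. "The series", "measured", "known", "first", "only" and "open" are said of these compounds alone.

Among the compounds with values here, in a functional assay on the whole organism (strain Wistar) for inhibition, with Rattus norvegicus as the target, read by paw edema, with stated times of 60 min and 6 h, at a dose of 100 mg/kg by the oral route (on this read-out higher numbers stand for more inhibition at the one dose given (going by the name of the read-out) and lower numbers for less inhibition), compound 1 `CNC(=O)CC1CCc2cc(OC)c(OC)cc21` gives 24.1%, the lower of the two numbers measured so far. Compound 2 `CCCCCNC(=O)CC1CCc2cc(OC)c(OC)cc21` gives 35.2%, and the step of a number 11.1 percentage points higher from compound 1 to compound 2 (beyond the scatter) shows that a larger group at the amide-type nitrogen went together with more inhibition. Compound 3 `COc1cc2c(cc1OC)C(CC(=O)N1CCCCC1)CC2` differs from compound 1 by piperidin-1-yl in place of methylamino on a carbonyl carbon; a larger group again sits on that nitrogen, though the amide hydrogen is lost. Within the data shown here, only this one step offers guidance, so a modest rise is expected, a number 7.9 percentage points higher from compound 1 to compound 3 (within the scatter). Compound 3 is therefore estimated at 32%, with a range from 18% to 46%.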

Compound 3, a percentage reported as inhibition, in the whole organism at one dose (the size of the read-out at that dose, not a potency): 31.5%
Beside the measured number, compound 3's estimate is 0.5 percentage points above it; the range from low to high includes it.
By their numbers in this assay, from the lowest: compounds 1, 3 and 2 (each within the scatter of the next, the first and the last beyond it).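

At this carbonyl carbon, the ring of piperidin-1-yl, which carries no hydrogen-bond donor, takes the place of an amino group that carries one, and in this assay inhibition persists: the change gives a number 7.4 percentage points higher from compound 1 to compound 3 (within the scatter) and a number 3.7 percentage points lower from compound 2 to compound 3 (within the scatter). Compound 3 therefore cannot be told apart from compound 1 or compound 2, so the amide hydrogen is not shown to be needed at this dose. No available evidence explains these numbers. Still open, from the compounds shown here alone, is how a morpholin-4-yl ring or an unsubstituted amino group would behave at this carbonyl carbon.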